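A few compounds are considered here, and "the series" means these few. Any claim that something is new, unique, unknown or untested is made for them only; others in the source may bear on it.

Three compounds have been measured in a functional assay on A2780 cells (Homo sapiens) for cytotoxicity, read by MTT assay, with a stated time of 48 h; a higher number here means a weaker inhibitor, a lower number a stronger inhibitor:

compound 1 `CCn1cc(-c2nc3ccccc3[nH]2)c(=O)c2cc(F)c(N3CCNC(C)C3)c(F)c21`: 11600 nM
compound 2 `CCn1cc(-c2nc3ccccc3o2)c(=O)c2cc(F)c(N3CCN(C)CC3)cc21`: 700 nM
compound 3 `CCn1cc(-c2nc3ccccc3s2)c(=O)c2cc(F)c(N3CCNCC3)nc21`: 2700 nM

Among these, compound 1 at 11600 nM has the highest number. Compound 3 is its nearest neighbour, and both compound 3 and compound 2 lie below it by more than the scatter. Compound 4 `CCn1cc(-c2nc3ccccc3s2)c(=O)c2cc(F)c(N3CCNC(C)C3)c(F)c21` is still unmeasured. It keeps the core of compound 1 and carries 1,3-benzothiazol-2-yl in place of 1H-benzimidazol-2-yl on an aromatic carbon.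

For the measured compounds named here, no pair of measured compounds differs in one place only, so this change has no direct precedent in the data. Going by the values given here, the only guide is indirect. Compound 3 carries the same 1,3-benzothiazol-2-yl and gives 2700 nM, but it also differs from compound 1 elsewhere, so its value is only a weak hint. On that basis a moderate step towards a lower number is expected, probably beyond the scatter, though a step within the scatter cannot be ruled out. The estimated step is a 3.3-fold lower number from compound 1 to compound 4 (0.52 log units; beyond the scatter). For compound 4 the estimated value is 3500 nM, with an expected range of 900 nM to 12000 nM.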

Compound 4, half-maximal inhibitory concentration: 9800 nM
The estimate for compound 4 lay 2.8-fold (0.45 log units) below the measured number, within the range that was stated.
By their numbers in this assay, from the lowest: compound 2; then compound 3; then compounds 4 and 1 (each within the scatter of the next).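

In this assay, for the compounds shown here, the first pair of compounds that differ in one place gives a 1.2-fold lower number from compound 1 to compound 4 (0.07 log units; within the scatter), so on the core of compound 1, 1,3-benzothiazol-2-yl and 1H-benzimidazol-2-yl on this aromatic carbon cannot be told apart. The exchange takes away the hydrogen-bond donor of the leaving group and brings sulfur into the five-membered aromatic ring, yet the two values stay within the scatter of each other, and compound 3, at 2700 nM, differs from compound 4 in more than one place and cannot be read against this step. The compounds shown offer no independent measurement that would account for this outcome.

Still open, going by these compounds, is whether a group of another kind on this aromatic carbon, such as a carboxylic acid or a simple phenyl, would move the number on the core of compound 1. Also open, on these data alone, is whether the same exchange would stay within the scatter on a different core, such as that of compound 2, which gives 700 nM and carries its own fused group.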